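The source may report more compounds than this note shows. Statements on the series, on what has been measured and on what is new or still open speak of the compounds shown alone.

Of the compounds shown here, three have so far been tested in a functional assay on the whole organism (strain CD1) for inhibition, with Mus musculus as the target, with stated times of 15 min and 20 min, at a dose of 10 mg/kg by the subcutaneous route; on this read-out lower numbers stand for less inhibition and higher numbers for more inhibition at the one dose given (going by the name of the read-out). Compound 1 `CCOC(=O)/C(C#N)=C/c1cocn1` carries the smallest aromatic portion of the set, and in this assay compound 1 gives 28.9%. Compound 2 `CC(C)(C)OC(=O)/C(C#N)=C/c1cc2ccccc2[nH]1` in this assay gives 51.3%, while compound 3 `CCCCCCCCCCCCOC(=O)/C(C#N)=C/c1cc2ccccc2[nH]1` in this assay gives 54.1%. Compound 2 therefore stands second of the three numbers: its figure exceeds that of compound 1 by a margin beyond the usual scatter, whereas its figure and that of compound 3 lie within the scatter of each other, so nothing separates those two. Compound 4 `N#C/C(=C\c1cc2ccccc2[nH]1)C(=O)NC1CCCCC1` has not yet been measured. It differs from compound 2 by cyclohexylamino in place of tert-butoxy on a carbonyl carbon. Among the compounds with values here, no pair of measured compounds differs in only one place, so no measured step guides this change, and the swap of an ester for an amide has no precedent in the set. The step of a number 1.3 percentage points lower from compound 2 to compound 4 (within the scatter) is expected to be small, in no clear direction, and not beyond the scatter. Compound 4 is therefore estimated at 50%, within a range from 30% to 70%.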

Compound 4, a percentage reported as inhibition, in the whole organism at one dose (the size of the read-out at that dose, not a potency): 45%
Compound 4: middle estimate off by 5 percentage points, on the high side; the measured number falls inside the stated range.
By their numbers in this assay, from the lowest: compound 1; then compounds 4, 2 and 3 (each within the scatter of the next).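

In this assay, within the data shown here, cyclohexylamino in place of tert-butoxy on a carbonyl carbon gives a number 6.3 percentage points lower from compound 2 to compound 4 (within the scatter), the first one-place change that can be read in this set. The exchange of an ester for an amide, which also brings in a six-membered non-aromatic ring of carbon only and a hydrogen-bond donor, therefore leaves the read-out at this position not separable from that of compound 2 at the one dose given. Nothing at hand bears on the reason for this outcome.

The compounds shown do not tell whether the amide link and the ring would each alone leave the number unchanged, which a tert-butylamino group on the same carbonyl carbon would address. From the compounds shown here alone, how a free carboxylic acid or a simple primary amide at this place would read also remains open.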